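The source may hold more compounds than are shown below. What is called first, only, known or untested is meant among the compounds shown, and "the series" means these compounds.

Measured so far in an assay on SK-BR-3 cells for inhibition of Aromatase (Homo sapiens); on this read-out higher numbers stand for weaker inhibition and lower numbers for stronger inhibition:
compound 1 `Cc1ccc(COc2cc([N+](=O)[O-])ccc2NS(C)(=O)=O)cc1` — 1750 nM
compound 2 `CS(=O)(=O)Nc1ccc([N+](=O)[O-])cc1OCc1ccc(F)cc1` — 580 nM

Among the measured compounds shown here, compound 2 stands lowest of the two numbers in this assay; its only neighbour is compound 1, separated by a 3.0-fold lower number from compound 1 to compound 2 (0.48 log units; beyond the scatter), a modest step. Compound 3 `CS(=O)(=O)Nc1ccc([N+](=O)[O-])cc1OCc1ccc(Br)cc1` differs from compound 2 by bromo in place of fluoro on an aromatic carbon. For the measured compounds named here, the single measured step, a 3.0-fold lower number from compound 1 to compound 2 (0.48 log units; beyond the scatter), changes the same aromatic position but exchanges methyl for fluoro, so bromo against fluoro has no direct precedent here. A small step is expected, within or near the scatter: a 1.1-fold higher number from compound 2 to compound 3 (0.05 log units; within the scatter). Compound 3 is estimated at 650 nM, with a range from 220 nM to 1900 nM.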

Compound 3, half-maximal inhibitory concentration: 5850 nM
Compound 3: the middle estimate sits 9.0-fold (0.95 log units) below what was measured, outside the stated range (above it).
By their numbers in this assay, from the lowest: compound 2; then compound 1; then compound 3.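

In this assay, exchanging one halogen for another on the aromatic carbon para to a large group is not a neutral change, with a 10-fold higher number from compound 2 to compound 3 (1.00 log units; beyond the scatter). Methyl does not mark an end of the range either: with a 3.3-fold higher number from compound 1 to compound 3 (0.52 log units; beyond the scatter), the two halogens fall on opposite sides of it, with fluoro giving the stronger and bromo the weaker inhibition. No evidence is available on what lies behind this order.

From the compounds shown here alone, whether chloro would fall between fluoro and bromo remains open. So does the standing of methoxy, trifluoromethyl or a bare hydrogen at this position.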